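This account rests on a few compounds, and the source may have more. Where it says the series, first, only, none or still open, it means among the compounds named here.

Measured compounds:
compound 1, `O=C(CCCCc1ccccc1)Nc1ccc(N2CCN(c3ccc(OC[C@@H]4CO[C@@](Cn5cncn5)(c5ccc(Cl)cc5Cl)O4)cc3)CC2)cc1`: > 50000 nM
compound 2, `O=C(Nc1ccc(N2CCN(c3ccc(OC[C@@H]4CO[C@@](Cn5cncn5)(c5ccc(Cl)cc5Cl)O4)cc3)CC2)cc1)C(/C=C/Cl)C/C=C/C(F)(F)F`: > 50000 nM

In a toxicity assay on L02 cells (Homo sapiens) for inhibition, read by MTT assay, with a stated time of 48 h (a higher number here means a weaker inhibitor, a lower number a stronger inhibitor), compound 1 gives > 50000 nM, which is a limit of the assay rather than a number. Compound 2 gives > 50000 nM in this assay, again a limit. Within the data shown here, the single measured step, a step that the two limits leave unreadable from compound 1 to compound 2, therefore has no readable size, and the limit of > 50000 nM in this assay, at which 2 of the 2 values shown sit, is all the evidence there is. Compound 3, `O=C(Nc1ccc(N2CCN(c3ccc(OC[C@@H]4CO[C@@](Cn5cncn5)(c5ccc(Cl)cc5Cl)O4)cc3)CC2)cc1)c1ccco1`, differs from compound 1 by furan-2-yl in place of 4-phenylbutyl on a carbonyl carbon. Among the measured compounds shown here, no measured step shows how a change at this carbonyl carbon moves the number in this assay; what is known is only that compound 1 and compound 2 both sit at the limit. From compound 1 to compound 3 the expected step is a number no higher from compound 1 to compound 3 (the limit leaves the size open), meaning no change that could be read beyond the scatter. Compound 3 is therefore expected to give about 50000 nM in this assay, within a range of 20000 nM to 200000 nM, and most likely to be reported as a limit once more.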

Compound 3, half-maximal inhibitory concentration: > 50000 nM
Compound 3 gave a limit, no number; the forecaster's own chance of this, stated with the estimate: 80%; the middle value sits exactly at the limit.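

The steps among compound 1, compound 2 and compound 3 cannot be read, because all three values are limits rather than numbers: the limit of > 50000 nM in this assay, at which 3 of the 3 values shown sit. Left open is whether any group on this carbonyl carbon gives a readable number in this assay at all.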